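The source may hold more compounds than are shown below. What is called first, only, known or untested is meant among the compounds shown, and "the series" means these compounds.

In an assay on isolated protein (Mus musculus) for inhibition of IL15-IL15 receptor (Homo sapiens), read by resazurin assay, with stated times of 30 min and 2.5 days (on this read-out higher numbers stand for weaker inhibition and lower numbers for stronger inhibition), the three measured compounds give the following numbers.

Compound 1 `CCCCCCCCCCSc1nnc(Cc2nn(C)c(=O)c3ccccc23)n1C`: 7600 nM
Compound 2 `Cc1ccc(NC(=O)CCCCCCCSc2nnc(Cc3nn(C)c(=O)c4ccccc34)n2C)c(Cl)c1`: 2300 nM
Compound 3 `CC(C)Oc1ccc(NC(=O)CCCCCCCSc2nnc(Cc3nn(C)c(=O)c4ccccc34)n2C)cc1`: 1100 nM

Compound 3 has the lowest number of the three, and so the strongest inhibition shown so far. Its nearest neighbour is compound 2, reached by the step of a 2.1-fold lower number from compound 2 to compound 3 (0.32 log units; beyond the scatter), a modest change that swapped one aryl group on the amide-type nitrogen for another. Compound 1 stands further off, with a number clearly higher than that of compound 3.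

Compound 4 `Cn1c(Cc2nn(C)c(=O)c3ccccc23)nnc1SCCCCCCCC(=O)Nc1ccc(O)cc1` differs from compound 3 in one place: hydrogen in place of isopropyl on an oxygen on an aromatic ring. Cut one bond further out, this reads as isopropoxy to hydroxy on the 4-hydroxyphenyl group. Of the measured steps, only a 2.1-fold lower number from compound 2 to compound 3 (0.32 log units; beyond the scatter) touches the same aryl group, and it was modest; a 3.3-fold lower number from compound 1 to compound 2 (0.52 log units; beyond the scatter) concerns the other end of the chain and does not bear on this change. Among the compounds with values here, no measured step removes an alkyl from an oxygen, so a step within the scatter is expected, a 1.4-fold higher number from compound 3 to compound 4 (0.13 log units; within the scatter). Compound 4 is therefore estimated at 1500 nM, with a range of 500 nM to 4500 nM.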

Compound 4, half-maximal inhibitory concentration: > 30000 nM
Compound 4 ended at the assay's limit (the forecaster's own chance of this, stated with the estimate: 5%); middle value at least 20-fold (1.30 log units) away from the limit.
By their numbers in this assay, from the lowest: compound 3; then compound 2; then compound 1. At a limit, above all of these: compound 4.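

In this assay compound 4 stands at a limit and not at a number: the limit of > 30000 nM in this assay, at which 1 of the 4 values shown sits. Taking the isopropyl group off this oxygen to leave hydroxy gives an at least 27-fold higher number from compound 3 to compound 4 (1.43 log units; beyond the scatter) in a single change, a far larger step than either of the earlier ones. Adding an aryl amide to the end of the chain lowered the number in compound 2 and compound 3, but compound 4 goes against this pattern, with an at least 13-fold higher number from compound 2 to compound 4 (1.11 log units; beyond the scatter) and an at least 3.9-fold higher number from compound 1 to compound 4 (0.59 log units; beyond the scatter) so the amide alone does not lower the number, and the group on the aryl ring decides the outcome.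

The compounds shown leave open whether the loss comes from the free hydroxy itself or from losing the alkyl group, and a methoxy or an amine at this place would help separate the two. From the compounds shown here alone, how far past the limit compound 4 truly lies also remains unknown.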